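The compounds below may be only part of what the source reports. "The series", "measured", "known", "first", "only" and "open" are said of these compounds alone.

Of the compounds shown here, two built on a shared core have been measured so far in an assay with sodium channel protein type 4 subunit alpha (Homo sapiens) as the target, read by patch clamp; on this read-out higher numbers stand for weaker inhibition and lower numbers for stronger inhibition. Compound 1, whose structure is `Nc1nc2c(s1)CC(CNC(=O)c1cc3ccccc3[nH]1)CC2`, gives 21000 nM in this assay. Compound 2, with the structure `Nc1nc2c(s1)C[C@@H](NC(=O)c1ccc[nH]1)CC2`, is the smaller of the two in its amide part. For compound 2 this assay reports only a limit, > 30000 nM, not a number. This is the limit of > 30000 nM in this assay, at which 1 of the 2 values shown sits, so compound 2 stands at the edge of what this assay can report, and its true position is known only as being at or beyond that edge.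

Compound 3, with the structure `Nc1nc2c(s1)C[C@@H](NC(=O)c1cc(Br)c[nH]1)CC2`, has not yet been measured. It differs from compound 2 in one place: bromo in place of hydrogen on an aromatic carbon. No measured pair in this set shows what such a change does, so there is no shown step to lean on. The step of an at least 1.2-fold lower number from compound 2 to compound 3 (0.07 log units; that floor lies within the scatter) is expected to be small, not beyond the usual scatter. Compound 3 is therefore expected to give about 25000 nM in this assay, with a range from 8000 nM to 80000 nM.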

Compound 3, half-maximal inhibitory concentration: > 30000 nM
Compound 3 was reported as a limit; the forecaster's own chance of this, stated with the estimate: 50%; at least 1.2-fold (0.07 log units) between middle value and limit.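

Going by these compounds alone, compound 2 and compound 3 both end at a limit of this assay rather than at a number, so no step between them can be read: the limit of > 30000 nM in this assay, at which 2 of the 3 values shown sit.

From the compounds shown here alone, what stays open is whether bromo in place of hydrogen on this aromatic carbon changes inhibition at all, and how far beyond the limit either compound truly lies.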